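Methyl on the ring amide nitrogen of compound 3

A few compounds are considered here, and "the series" means these few. Any claim that something is new, unique, unknown or untested is made for them only; others in the source may bear on it.

The shared core of these compounds is a fused two-ring system carrying a phenyl group, seen in compound 1 `CCc1nn(C)c2c1C(c1ccccc1)=NCC(=O)N2`. In a functional assay on the whole organism with Rattus norvegicus as the target (on this read-out higher numbers stand for an effect only at larger amounts of compound and lower numbers for an effect already at smaller amounts), compound 1 gives 8 mg/kg. Compound 2 `CCc1nn(C)c2c1C(c1ccccc1F)=NCC(=O)N2` carries a fluorine on the phenyl ring and in this assay compound 2 gives 2 mg/kg; 2 mg/kg (2 entries). Going by the values given here, compound 3 `CCc1nn(C)c2c1C(c1cccc(F)c1)=NCC(=O)N2` carries the fluorine elsewhere on the phenyl ring, and in this assay compound 3 gives 32 mg/kg, the higher of the two single numbers; the only counted step, a 4.0-fold higher number from compound 1 to compound 3 (0.60 log units; beyond the scatter), lies beyond the scatter.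

Compound 4 `CCc1nn(C)c2c1C(c1cccc(F)c1)=NCC(=O)N2C` differs from compound 3 by methyl in place of hydrogen on an amide-type nitrogen in a ring. Among the compounds with values here, no measured step touches the ring nitrogen: the one step on record concerns fluoro in place of hydrogen on an aromatic carbon, so it offers no direct guidance. With nothing pointing either way, the number for compound 4 is expected to stay close to that of compound 3, with no change at the digits printed from compound 3 to compound 4 (within the scatter) expected to fall within the scatter. Compound 4 is therefore estimated at 32 mg/kg, within a range from 8 mg/kg to 128 mg/kg.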

Compound 4, minimum effective dose: 32 mg/kg
Beside the measured number, compound 4's estimate shows no gap at the digits printed, and the stated range covers the measured number.
By their numbers in this assay, from the lowest: compound 1; then compounds 3 and 4 (each within the scatter of the next).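

In this assay, going by these compounds alone, the first reading at this position is no change at the digits printed from compound 3 to compound 4 (within the scatter), so methyl in place of the amide hydrogen on this ring nitrogen leaves the number within the scatter, in this one pair with the 3-fluorophenyl group in place. Within the data shown here, the earlier compounds varied only the phenyl ring, where the one counted step, a 4.0-fold higher number from compound 1 to compound 3 (0.60 log units; beyond the scatter), lay beyond the scatter, whereas this change elsewhere on the seven-membered ring shows no such shift. No measurement offered here explains this result.

Going by these compounds, whether methyl on this nitrogen would read the same in compound 1 or compound 2, which carry a different phenyl group, remains open. So does whether a longer chain such as benzyl, or a chain ending in an amine or a carboxylic acid, would be tolerated on the same nitrogen.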